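The compounds below may be only part of what the source reports. "The series", "measured", "known", "first", "only" and "open" are said of these compounds alone.

The measured compounds:
compound 1 `Cc1ccccc1-n1c(Nc2nc(-c3ccccc3)cs2)n[nH]c1=S`, 100 mg/kg
compound 2 `COc1ccc(-n2c(Nc3nc(-c4ccc([N+](=O)[O-])cc4)cs3)n[nH]c2=S)cc1`, 100 mg/kg
compound 3 `S=c1[nH]nc(Nc2nc(-c3ccccc3)cs2)n1-c1ccccc1`, 300 mg/kg

In a functional assay on the whole organism (strain Swiss albino) for inhibition, with Mus musculus as the target, with a stated time of 0.5 h (a higher number here means that more compound is needed for the effect, a lower number that less compound is needed), compound 1 gives 100 mg/kg. Compound 1 stands level with compound 2 at the digits recorded, and together the two hold the lowest numbers of the three; compound 3 lies furthest from compound 1, with a 3.0-fold higher number from compound 1 to compound 3 (0.48 log units; beyond the scatter).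

Compound 4 `Cc1ccccc1-n1c(Nc2nc(-c3ccc([N+](=O)[O-])cc3)cs2)n[nH]c1=S` is not yet measured. It differs from compound 1 in one place: nitro in place of hydrogen on an aromatic carbon. Within the data shown here, no measured step isolates this change. Among the measured compounds shown here, the single step on record, a 3.0-fold higher number from compound 1 to compound 3 (0.48 log units; beyond the scatter), concerns hydrogen in place of methyl on a different ring and says nothing about a nitro group. Compound 2, which also bears a nitro group, gives 100 mg/kg, the same as compound 1 at the digits recorded. On that basis no step beyond the scatter is expected in this assay. Compound 4 is therefore estimated at 100 mg/kg, with a range from 50 mg/kg to 300 mg/kg, which is expected to mean no change at the digits printed from compound 1 to compound 4 (within the scatter).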

Compound 4, minimum effective dose: 100 mg/kg
The estimate for compound 4 equals the measured number at the digits printed; the range from low to high includes it.
By their numbers in this assay, from the lowest: compounds 1, 2 and 4 (each within the scatter of the next); then compound 3.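

In this assay, among these compounds, the nitro group, placed para to a large group, gives no change at the digits printed from compound 1 to compound 4 (within the scatter) and thus supplies the first measured step for phenyl to 4-nitrophenyl, with the 2-methylphenyl group held on the aromatic nitrogen. With the 4-nitrophenyl group held instead, 2-methylphenyl in place of 4-methoxyphenyl gives no change at the digits printed from compound 2 to compound 4 (within the scatter), so this assay does not separate these two groups on the aromatic nitrogen in this setting. No measurement offered here accounts for either step.

Going by these compounds, whether nitro in this place leaves the number equally undisturbed with the unsubstituted phenyl of compound 3 on the aromatic nitrogen remains open. So does the outcome for an amine or a carboxylic acid at the same ring carbon, where only hydrogen and nitro are compared.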